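Replacing a Ring Halogen with a Methyl on the Phenoxy Group

The source may report more compounds than this note shows. Statements on the series, on what has been measured and on what is new or still open speak of the compounds shown alone.

Compound 1, `Cc1nn(C)c(Oc2cccc(Cl)c2)c1/C=N\CCCCCCOc1cc2oc(=O)cc(C)c2cc1Cl`, gives 6220 nM in a functional assay on HepG2 cells (Homo sapiens) for antiproliferative activity, read by MTT assay, with a stated time of 72 h; on this read-out lower numbers stand for stronger inhibition and higher numbers for weaker inhibition.
Compound 2, `Cc1nn(C)c(Oc2cccc(Br)c2)c1/C=N\CCCCCCOc1cc2oc(=O)cc(C)c2cc1Cl`, gives 6830 nM in this assay.

Only these two compounds have been measured, and they are separated by a 1.1-fold higher number from compound 1 to compound 2 (0.04 log units; within the scatter), a difference that falls within the scatter, so compound 2 stands alongside compound 1 rather than apart from it. Compound 3, `Cc1ccccc1Oc1c(/C=N\CCCCCCOc2cc3oc(=O)cc(C)c3cc2Cl)c(C)nn1C`, carries the change (2-methylphenyl in place of 3-bromophenyl on an oxygen on an aromatic ring). Among the measured compounds shown here, the single measured step, exchanging one halogen for another, is the only evidence available, and it showed no movement beyond the scatter; it does not directly cover a switch to a 2-methylphenyl, so the expectation rests on it loosely. The step from compound 2 to compound 3 is therefore expected to be small, a 1.1-fold lower number from compound 2 to compound 3 (0.02 log units; within the scatter), in no firm direction. Compound 3 is estimated at 6500 nM, with a range from 2500 nM to 17000 nM.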

Compound 3, half-maximal inhibitory concentration: 7830 nM
Compound 3: middle estimate off by 1.2-fold (0.08 log units), on the low side; low and high end bracket the measured number.
By their numbers in this assay, from the lowest: compounds 1, 2 and 3 (each within the scatter of the next).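

Putting a 2-methylphenyl in place of the 3-bromophenyl on the oxygen gives a 1.1-fold higher number from compound 2 to compound 3 (0.06 log units; within the scatter), and putting it in place of the 3-chlorophenyl gives a 1.3-fold higher number from compound 1 to compound 3 (0.10 log units; within the scatter). The earlier pair only exchanged one halogen for another, whereas here a group with no halogen at all, made of carbon only, enters the same place, and in this assay the numbers still stay within the scatter of each other. Nothing available explains why this position tolerates the exchange.

Going by these compounds, all three compounds carry a substituted phenyl ring on this oxygen, so whether an amine or a carboxylic acid on that ring would move the number stays open. So does the outcome of putting a longer chain on the oxygen in place of the ring.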